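Hydroxy to trifluoromethoxy at the limit of the assay

The source may hold more compounds than are shown below. What is called first, only, known or untested is meant among the compounds shown, and "the series" means these compounds.

compound 1 `Cn1c(=O)c(=O)n(C2CCCC2)c2nc(N/N=C/c3ccc(O)cc3)ncc21` gives > 100000 nM (a limit)
compound 2 `Cn1c(=O)c(=O)n(C2CCCC2)c2nc(N/N=C/c3cccc(O)c3)ncc21` gives > 100000 nM (a limit)

Both compounds were tested in a functional assay on A549 cells (Homo sapiens) for antiproliferative activity, read by MTT assay (on this read-out higher numbers stand for weaker inhibition and lower numbers for stronger inhibition), and neither gave a number. Compound 1 stands at the limit of > 100000 nM in this assay, at which 2 of the 2 values shown sit, and so has only a limit to its name.

Compound 3 `Cn1c(=O)c(=O)n(C2CCCC2)c2nc(N/N=C/c3ccc(OC(F)(F)F)cc3)ncc21` keeps the core of compound 1 but carries trifluoromethoxy in place of hydroxy, the difference being trifluoromethyl in place of hydrogen on an oxygen on an aromatic ring and nothing else. Within the data shown here, the only measured step is a step that the two limits leave unreadable from compound 1 to compound 2 and it offers no size to carry over. Among the measured compounds shown here, no measured step touches this change, so its size is open. Only a step towards stronger inhibition could appear as a number in this assay and a moderate one is expected. The expected move is an at least 2.5-fold lower number from compound 1 to compound 3 (0.39 log units; beyond the scatter) as an estimate, and another limit remains quite possible. For compound 3 the estimated value is 40000 nM, expected to lie between 8000 nM and 100000 nM as its range.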

Compound 3, half-maximal inhibitory concentration: 12900 nM
Estimate against measurement, compound 3: 3.1-fold (0.49 log units) above, within the range that was stated.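

In this assay, among these compounds, capping the hydroxy oxygen with trifluoromethyl gives the only true number among the three compounds, a change read as an at least 7.7-fold lower number from compound 1 to compound 3 (0.88 log units; beyond the scatter). The two hydroxyphenyl compounds had shown only that neither placing of the hydroxy group gave a number, and the step between them cannot be read. This position on the aromatic ring therefore responds to the group it carries, although the step has only a lower bound because compound 1 is held at a limit: the limit of > 100000 nM in this assay, at which 2 of the 3 values shown sit.

The compounds shown leave open how far the effect depends on the fluorines, since a methoxy group on the same oxygen would separate the capping of the hydroxy group from the trifluoromethyl group itself. They also leave open whether an amine or a carboxylic acid at this place would give a number in this assay.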